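A few compounds are considered here, and "the series" means these few. Any claim that something is new, unique, unknown or untested is made for them only; others in the source may bear on it.

Working notes on the series. Three compounds of the shared core have values in a functional assay on SW480 cells (Homo sapiens) for antiproliferative activity, read by MTT assay, with a stated time of 72 h; on this read-out lower numbers stand for stronger inhibition and higher numbers for weaker inhibition. Compound 1 `Cc1ccc2c(=O)c(CSC(=S)N3CCCCC3)coc2c1` carries piperidin-1-yl on the thiocarbonyl carbon; in this assay compound 1 reaches only a limit of > 25000 nM. Compound 2 `O=c1c(CSC(=S)N2CCOCC2)coc2cc(Cl)ccc12` gives 6200 nM in this assay. Compound 3 `Cc1ccc2c(=O)c(CSC(=S)N3CCCC3)coc2c1` gives 5900 nM in this assay. Compound 3 thus has the lowest of the two numbers, with compound 2 within the scatter of it; the remaining value is a limit (the limit of > 25000 nM in this assay, at which 1 of the 3 values shown sits). Among the measured compounds shown here, the one step measured in one place is pyrrolidin-1-yl in place of piperidin-1-yl, an at least 4.2-fold lower number from compound 1 to compound 3 (0.62 log units; beyond the scatter), and this is the only change in the ring on the thiocarbonyl carbon that can be sized here.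

Compound 4 `Cc1ccc2c(=O)c(CSC(=S)N3CCOCC3)coc2c1` is not yet measured. It differs from compound 3 by morpholin-4-yl in place of pyrrolidin-1-yl on a thiocarbonyl carbon. For the measured compounds named here, no measured step covers this exact change; compound 2 and compound 3 differ in the morpholin-4-yl against pyrrolidin-1-yl and also in the chloro against methyl on the core, and their values lie within the scatter of each other. Given the step from compound 1 to compound 3, a six-membered ring here can carry a weaker number, yet compound 2 shows morpholin-4-yl with a number close to compound 3. The expected step in this assay is therefore small, a 1.4-fold higher number from compound 3 to compound 4 (0.13 log units; within the scatter), in the direction of a somewhat higher number. For compound 4 the estimated value is 8000 nM, within a range of 3500 nM to 20000 nM.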

Compound 4, half-maximal inhibitory concentration: 3800 nM
Compound 4: the middle estimate sits 2.1-fold (0.32 log units) above what was measured; the range from low to high includes it.
By their numbers in this assay, from the lowest: compounds 4, 3 and 2 (each within the scatter of the next). At a limit, above all of these: compound 1.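

In this assay, among the compounds shown here, morpholin-4-yl and pyrrolidin-1-yl on the thiocarbonyl carbon cannot be told apart (with a 1.6-fold lower number from compound 3 to compound 4 (0.19 log units; within the scatter)), which is the first direct reading of this change without a second difference on the core. The change on the core can now also be sized on its own, and methyl in place of chloro on an aromatic carbon leaves the number within the scatter as well (with a 1.6-fold lower number from compound 2 to compound 4 (0.21 log units; within the scatter)). Compound 4 carries a six-membered ring and still separates from the piperidin-1-yl of compound 1 (with an at least 6.5-fold lower number from compound 1 to compound 4 (0.81 log units; beyond the scatter)), so ring size alone does not set the number on this carbon, and this step rests on a limit, not a number: the limit of > 25000 nM in this assay, at which 1 of the 4 values shown sits.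

Going by these compounds, what an open-chain amine such as diethylamino or a ring with a second nitrogen such as piperazin-1-yl would give on the thiocarbonyl carbon stays open. The compounds shown pair chloro on the core only with morpholin-4-yl, so it also stays open whether piperidin-1-yl keeps its separation from the other rings with chloro in place of methyl.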